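This account rests on a few compounds, and the source may have more. Where it says the series, first, only, none or still open, it means among the compounds named here.

Of the compounds shown here, three have been measured in an assay on nucleic acid for inhibition of Nucleic Acid, read by fluorescence, tested at 100 uM; a higher number here means more inhibition at the concentration tested (going by the name of the read-out), a lower number less inhibition. Compound 1 `CN(CCCc1ccccc1)Cc1cn(CC(O)COC(=O)NCc2ccccc2)nn1` gives 79%. Compound 2 `CN(CCCc1ccccc1)Cc1cn(CC(O)COCc2ccccc2)nn1` gives 18%, and the one-place change between them, benzyl in place of benzylcarbamoyl on an oxygen on a saturated carbon, reads a number 61 percentage points lower from compound 1 to compound 2 (beyond the scatter). Compound 3 `CC(C)CCN(C)Cc1cn(CC(O)COC(=O)c2ccccc2)nn1` gives 0%, the lowest of the three numbers: compound 2 stands beyond the scatter above it, and compound 1 further still.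

The next compound, compound 4 `CN(CCCc1ccccc1)Cc1cn(CC(O)COC(=O)c2ccccc2)nn1`, is compound 3 with one change: benzyl in place of isopropyl on a saturated chain carbon, two bonds along the chain from an amine nitrogen. Among the compounds with values here, the only measured step concerns a different part of the molecule, the group on the oxygen, so it does not speak to this change. What can be said is that both compounds carrying 3-phenylpropyl, compound 1 and compound 2, gave more than compound 3, while the oxygen-bound group of compound 4 is that of compound 3 and of neither. A modest rise is therefore expected, a number 25 percentage points higher from compound 3 to compound 4 (beyond the scatter), with wide uncertainty. The estimate for compound 4 is 25%, in a range from 0% to 60%.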

Compound 4, a percentage reported as inhibition, at one concentration (the size of the read-out at that concentration, not a potency): 12%
Estimate against measurement, compound 4: 13 percentage points above; the range from low to high includes it.
By their numbers in this assay, from the lowest: compound 3; then compounds 4 and 2 (each within the scatter of the next); then compound 1.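

In this assay, with benzoyl held on the oxygen, benzyl in place of isopropyl on a saturated chain carbon, two bonds along the chain from an amine nitrogen, reads a number 12 percentage points higher from compound 3 to compound 4 (beyond the scatter) and so shows that this part of the molecule moves the number only modestly. On the oxygen, benzoyl in place of benzyl reads a number 6 percentage points lower from compound 2 to compound 4 (within the scatter) and does not separate these two groups. Phenyl in place of benzylamino on a carbonyl carbon reads a number 67 percentage points lower from compound 1 to compound 4 (beyond the scatter) and so, among the three compounds with 3-phenylpropyl, only compound 1 with its benzylcarbamoyl group stands high.

Going by these compounds, it remains open whether benzylcarbamoyl would raise the number with isopentyl in the chain, and what a methylcarbamoyl group on the oxygen or a chain longer than 3-phenylpropyl would read. Nothing available explains the size of these steps.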